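Halobenzyl series against biotin--protein ligase: positional isomers

The compounds below may be only part of what the source reports. "The series", "measured", "known", "first", "only" and "open" are said of these compounds alone.

Measured so far:
- compound 1 `O=C1N[C@H]2[C@H](CS[C@H]2CCCCCc2cn(Cc3ccc(F)cc3)nn2)N1`: > 16000 nM
- compound 2 `O=C1N[C@H]2[C@H](CS[C@H]2CCCCCc2cn(Cc3ccccc3Cl)nn2)N1`: > 16000 nM
- compound 3 `O=C1N[C@H]2[C@H](CS[C@H]2CCCCCc2cn(Cc3cccc(Cl)c3)nn2)N1`: > 16000 nM

In an assay on isolated protein for inhibition of biotin--protein ligase (Homo sapiens), read by scintillation counting, with a stated time of 10 min (on this read-out higher numbers stand for weaker inhibition and lower numbers for stronger inhibition), compound 1 gives > 16000 nM, which is a limit of the assay and not a number. Compound 2 likewise gives > 16000 nM in this assay, again a limit. Compound 3 gives > 16000 nM, also a limit. Among the measured compounds shown here, compound 3 therefore stands nowhere that can be ranked: all three values sit at the limit of > 16000 nM in this assay, at which 3 of the 3 values shown sit, and no compound can be called stronger or weaker than another.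

The three pairwise steps are accordingly unreadable: a step that the two limits leave unreadable from compound 1 to compound 2, a step that the two limits leave unreadable from compound 1 to compound 3 and a step that the two limits leave unreadable from compound 2 to compound 3. What they show is only that exchanging one halophenyl for another on the saturated chain carbon bound to the aromatic nitrogen has not brought any compound inside the measurable range.

Compound 4 `O=C1N[C@H]2[C@H](CS[C@H]2CCCCCc2cn(Cc3ccc(Cl)cc3)nn2)N1` is the next positional isomer, differing from compound 3 by 4-chlorophenyl in place of 3-chlorophenyl on a saturated chain carbon bound to an aromatic nitrogen. The measured steps bear on it in that every such exchange so far has left the value at the limit; no readable size is available, so no step beyond the scatter is expected in this assay, and a further limit is the most likely outcome. Compound 4 is therefore expected near 30000 nM, with a range from 12000 nM to 120000 nM. The expected step from compound 3 is a step that the limit leaves unreadable from compound 3 to compound 4.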

Compound 4, inhibition constant: > 16000 nM
Compound 4: a limit, no number; the forecaster's own chance of this, stated with the estimate: 85%; the middle value does not contradict the limit.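

In this assay compound 4 gives > 16000 nM, which is a limit and not a number. No step from compound 1, compound 2 or compound 3 to compound 4 can be read: the limit of > 16000 nM in this assay, at which 4 of the 4 values shown sit.

The compounds shown leave open how these four rank against one another and whether any halobenzyl group on the shared core reaches the measurable range.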